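From a Fluorinated Aryl Amide to a Cyclohexenyl Amide

This account rests on a few compounds, and the source may have more. Where it says the series, first, only, none or still open, it means among the compounds named here.

Compound 1 `COc1cccc(C(=O)Nc2cc(-c3ccccc3)nn2-c2ccccc2)c1`: in a functional assay on cells for positive allosteric modulation of metabotropic glutamate receptor 5 (Rattus norvegicus), read by calcium flux (on this read-out lower numbers stand for an effect already at smaller amounts and higher numbers for an effect only at larger amounts of compound), compound 1 gives 102 nM.
Compound 2 `O=C(Nc1cc(-c2ccccc2)nn1-c1ccccc1)c1ccc(OC(F)(F)F)cc1`: in this assay compound 2 gives 18 nM.
Compound 3 `O=C(Nc1cc(-c2ccccc2)nn1-c1ccccc1)c1ccc(C(F)(F)F)cc1`: in this assay compound 3 gives 38 nM.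

Among these three numbers compound 3 stands second highest, with compound 2 nearest and compound 1 furthest. Compound 4 `O=C(Nc1cc(-c2ccccc2)nn1-c1ccccc1)C1=CCCCC1` differs from compound 3 by cyclohex-1-en-1-yl in place of 4-(trifluoromethyl)phenyl on a carbonyl carbon. Two measured steps change the group on the same carbonyl carbon: a 2.7-fold lower number from compound 1 to compound 3 (0.43 log units; beyond the scatter) and a 2.1-fold higher number from compound 2 to compound 3 (0.32 log units; beyond the scatter), both modest. Among the measured compounds shown here, neither of them trades the aromatic ring for a non-aromatic one, so no measured step bears directly on this change, and the expectation rests loosely on the size of those aryl exchanges. The author expects a 3.9-fold higher number from compound 3 to compound 4 (0.60 log units; beyond the scatter), a step towards a higher number. For compound 4 the estimate in this assay is 150 nM, between 40 nM and 600 nM.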

Compound 4, half-maximal effective concentration: 3300 nM
For compound 4 the middle estimate is 22-fold (1.34 log units) below the measured one; the whole stated range lies below it.
By their numbers in this assay, from the lowest: compound 2; then compound 3; then compound 1; then compound 4.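

Compared with the modest aryl exchanges on this carbonyl carbon, replacing the aromatic ring with cyclohex-1-en-1-yl has a far greater effect in this assay, giving an 87-fold higher number from compound 3 to compound 4 (1.94 log units; beyond the scatter) and a 32-fold higher number from compound 1 to compound 4 (1.51 log units; beyond the scatter) as two large steps. The aromatic ring thus gave way to a non-aromatic one with a much higher number from both starting points, whether the departing aryl group carried trifluoromethyl or methoxy. Nothing available here gives a reason for this.

On these data alone, it remains open whether cyclohexyl or piperidine on this carbonyl carbon would stay near compound 4, or whether unsubstituted phenyl would return towards compound 3.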